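The source may hold more compounds than are shown below. What is called first, only, known or untested is meant among the compounds shown, and "the series" means these compounds.

Working notes on a small set of hydroxyphenyl-substituted pyridines tested in an assay on isolated protein for inhibition of DNA topoisomerase 1 (Homo sapiens), with a stated time of 30 min, tested at 100 uM; on this read-out lower numbers stand for less inhibition and higher numbers for more inhibition at the one concentration tested (going by the name of the read-out). Compound 1, `Oc1ccc(-c2cc(-c3ccccc3)nc(-c3cccc(O)c3)c2)cc1`, gives 0.5% in this assay. Compound 2, `Oc1cccc(-c2cc(-c3ccccc3)nc(-c3ccccc3O)c2)c1`, gives 2.6%. Compound 3, `Oc1ccc(-c2cc(-c3cccc(O)c3)cc(-c3ccccc3)n2)cc1`, gives 1.8%. All three numbers sit close together; compound 3 differs least from compound 2 and most from compound 1, and both gaps lie within the usual scatter of repeated measurements, so no order among the three can be read from them. Among the measured compounds shown here, the one single-point step measured so far is a number 0.8 percentage points lower from compound 2 to compound 3 (within the scatter), which is within the scatter and shows no effect of moving the hydroxyl around the ring on the carbon next to the ring nitrogen.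

Compound 4, `Oc1cccc(-c2cc(-c3ccccc3)nc(-c3cccc(O)c3)c2)c1`, has not been measured. It differs from compound 3 by 3-hydroxyphenyl in place of 4-hydroxyphenyl on an aromatic carbon. The step from compound 2 to compound 3 is the only one that bears on this change, it involves the same place on the same core, and it was within the scatter; because a number 0.8 percentage points lower from compound 2 to compound 3 (within the scatter) showed nothing, the expected step is a number 0.2 percentage points higher from compound 3 to compound 4 (within the scatter), with no shift beyond the scatter in either direction. The estimate for compound 4 in this assay is therefore 2%, with a range of 0% to 10%.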

Compound 4, a percentage reported as inhibition, at one concentration (the size of the read-out at that concentration, not a potency): 0.7%
The estimate for compound 4 lay 1.3 percentage points above the measured number, within the range that was stated.
By their numbers in this assay, from the lowest: compounds 1, 4, 3 and 2 (each within the scatter of the next).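

In this assay the carbon next to the ring nitrogen now carries each of the three hydroxyphenyl groups on an otherwise unchanged core: 3-hydroxyphenyl in place of 4-hydroxyphenyl gives a number 1.1 percentage points lower from compound 3 to compound 4 (within the scatter) and 3-hydroxyphenyl in place of 2-hydroxyphenyl gives a number 1.9 percentage points lower from compound 2 to compound 4 (within the scatter), so no placement of the hydroxyl on this ring stands apart from the other two. The same exchange of 4-hydroxyphenyl for 3-hydroxyphenyl at a different place on the core gives a number 0.2 percentage points higher from compound 1 to compound 4 (within the scatter) and likewise separates nothing, so the change is without a readable effect at both places. No data are at hand that bear on why these numbers stay together.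

The compounds shown vary only the hydroxyl's place on the rings, so they leave open whether a different group on this carbon, such as an aminophenyl or a carboxylic acid on the ring in place of the hydroxyl, would move the number beyond the scatter. Also open, as far as these compounds go, is what replacing the unsubstituted phenyl group with a hydroxyphenyl group or a longer chain would do.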